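A few compounds are considered here, and "the series" means these few. Any claim that something is new, unique, unknown or untested is made for them only; others in the source may bear on it.

Measured in a functional assay on A549 cells (Homo sapiens) for cytotoxicity, read by MTT assay, with a stated time of 72 h; on this read-out lower numbers stand for stronger inhibition and higher numbers for weaker inhibition:
- Compound 1 `CNC(=O)c1cc(Oc2ccc(C3=NNC(c4ccc(C#N)cc4)C3)cc2)ccn1`: 17400 nM
- Compound 2 `CNC(=O)c1cc(Oc2ccc(C3=NN(C(N)=S)C(c4ccc(F)cc4)C3)cc2)ccn1`: 19400 nM
- Compound 3 `CNC(=O)c1cc(Oc2ccc(C3=NN(C(N)=S)C(c4cccc(Cl)c4Cl)C3)cc2)ccn1`: > 50000 nM, a limit of the assay and not a number

Compound 3 has only a limit on this scale, and it sits at the limit of > 50000 nM in this assay, at which 1 of the 3 values shown sits. Compound 4 `CNC(=O)c1cc(Oc2ccc(C3=NN(C(N)=S)C(c4ccc(C#N)cc4)C3)cc2)ccn1` has not yet been measured. The change leading to it is 4-cyanophenyl in place of 2,3-dichlorophenyl on a saturated ring carbon: 4-cyanophenyl takes the place of 2,3-dichlorophenyl on a saturated ring carbon of the five-membered non-aromatic ring.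

Going by the values given here, the one measured step at this carbon is an at least 2.5-fold higher number from compound 2 to compound 3 (0.41 log units; beyond the scatter), with 2,3-dichlorophenyl in place of 4-fluorophenyl. The new change removes that same 2,3-dichlorophenyl group, so a move back towards a lower number is expected, of at least similar size. Two further values help to place it. Compound 2, with 4-fluorophenyl, gives 19400 nM. Compound 1 also carries 4-cyanophenyl and gives 17400 nM. Among the compounds with values here, with only three compounds, and one of them a limit, this expectation remains loose.

The expected change is an at least 2.7-fold lower number from compound 3 to compound 4 (0.44 log units; beyond the scatter). For compound 4 the estimated value in this assay is 18000 nM, with an expected range from 7000 nM to 45000 nM.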

Compound 4, half-maximal inhibitory concentration: > 50000 nM
Compound 4: no number, only a limit; the forecaster's own chance of this, stated with the estimate: 12%; middle value at least 2.7-fold (0.44 log units) from the limit.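

In this assay compound 4 gives > 50000 nM, a limit of the assay and not a number, so 4-cyanophenyl in place of 2,3-dichlorophenyl on this saturated ring carbon does not bring back a measurable value, and the step between these two limits cannot be read. Going by these compounds alone, the 2,3-dichlorophenyl group is therefore not the only group at this carbon that goes with a weaker result, since cyano in place of fluoro on an aromatic carbon gives an at least 2.5-fold higher number from compound 2 to compound 4 (0.41 log units; beyond the scatter). The same 4-cyanophenyl group also behaves differently depending on what sits on the ring nitrogen: a group of 3 heavy atoms (1 carbon, 1 nitrogen, 1 sulfur) in place of a hydrogen atom on that amine nitrogen gives an at least 2.8-fold higher number from compound 1 to compound 4 (0.45 log units; beyond the scatter).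

As far as these compounds go, how far compound 3 and compound 4 really lie from the measured compounds stays unknown, and the two cannot be ranked against each other: the limit of > 50000 nM in this assay, at which 2 of the 4 values shown sit. Also open is whether a 4-aminophenyl or a 4-carboxyphenyl group on this saturated ring carbon would stay measurable in this assay with the group of 3 heavy atoms in place.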